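The source may report more compounds than this note shows. Statements on the series, on what has been measured and on what is new or still open speak of the compounds shown alone.

Measured compounds in a functional assay on the whole organism for antagonist activity, with Mus musculus as the target; on this read-out lower numbers stand for an effect already at smaller amounts and higher numbers for an effect only at larger amounts of compound:
Compound 1, `CC(C#CCn1ccnc1)N1CCCC1=O`, gives 45 mg/kg.
Compound 2, `CC(C#CCN(C)C)N1CCCC1=O`, gives only a limit of the assay, > 100 mg/kg.
Compound 3, `COC(=O)N(C)CC#CCn1ccnc1`, gives only a limit of the assay, > 100 mg/kg.

Compound 1 and compound 2 differ in one place: dimethylamino in place of 1H-imidazol-1-yl on a saturated chain carbon bound to a triple-bonded carbon. In this assay this change makes an at least 2.2-fold higher number from compound 1 to compound 2 (0.34 log units; beyond the scatter), and what is known about the size of that step is bounded by the limit of > 100 mg/kg in this assay, at which 2 of the 3 values shown sit. Compound 3 carries a different core from compound 1; the difference between the two cores is not broken down here. Compound 4, `COC(=O)N(C)CC#CCN(C)C`, has not yet been measured in this assay. Among the compounds with values here, it differs from compound 3 by dimethylamino in place of 1H-imidazol-1-yl on a saturated chain carbon bound to a triple-bonded carbon, the same change as the one from compound 1 to compound 2. The expectation for compound 4 rests on compound 3, which in this assay already gives only a limit, > 100 mg/kg. It rests further on the step of an at least 2.2-fold higher number from compound 1 to compound 2 (0.34 log units; beyond the scatter), which ended at the limit of > 100 mg/kg in this assay, at which 2 of the 3 values shown sit. Compound 4 is therefore expected to reach about 220 mg/kg, estimated to lie between 100 mg/kg and 600 mg/kg. This estimate amounts to an expected step that the limit leaves unreadable from compound 3 to compound 4.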

Compound 4, dose for half-maximal effect: > 30 mg/kg
Compound 4: only a limit was reported; the forecaster's own chance of this, stated with the estimate: 85%; the middle value lies beyond the limit too.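

In this assay, compound 3 and compound 4 each give only a limit of the assay, so no step can be read between compound 3 and compound 4. The compounds shown leave open whether dimethylamino in place of 1H-imidazol-1-yl acts on the core of compound 3 as it does on the core of compound 1.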